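This account rests on a few compounds, and the source may have more. Where it says the series, first, only, none or still open, it means among the compounds named here.

Working notes on the series. Compound 1 `CCC(C(=O)NCc1ccccc1C(F)(F)F)N1C(=O)CCC1=O` carries a trifluoromethyl on the benzylic ring and an ethyl side chain on the shared core. In a functional assay on the whole organism (strain Albino Swiss CD1) with Mus musculus as the target, in the maximal electroshock model (on this read-out lower numbers stand for an effect already at smaller amounts and higher numbers for an effect only at larger amounts of compound), compound 1 returns only a limit, > 150 mg/kg, so no number exists for it. For the measured compounds named here, compound 2 `CC1CC(=O)N(C(C)C(=O)NCc2ccccc2)C1=O`, with a methyl on the shared core and a methyl side chain, is the only member with a number: in this assay compound 2 gives 106 mg/kg. The other value shown is the limit of > 150 mg/kg in this assay, at which 1 of the 2 values shown sits, and that one belongs to compound 1. Going by the values given here, no step between two measured compounds can be drawn from these two, so compound 2 alone anchors the series.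

Compound 3 `CC1CC(=O)N(C(C)C(=O)NCc2ccccc2F)C1=O` differs from compound 2 by fluoro in place of hydrogen on an aromatic carbon, in words: fluoro in place of hydrogen on an aromatic carbon. With nothing measured on this change, the step of a 1.2-fold lower number from compound 2 to compound 3 (0.10 log units; within the scatter) is expected to stay within the usual scatter or to move only slightly toward smaller doses. In this assay compound 3 is therefore estimated at 85 mg/kg, with a range from 40 mg/kg to 180 mg/kg.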

Compound 3, dose for half-maximal effect: 80.5 mg/kg
Compound 3: middle estimate off by 1.1-fold (0.02 log units), on the high side; measured number inside the range.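

The series now holds its first step between two measured compounds, a 1.3-fold lower number from compound 2 to compound 3 (0.12 log units; within the scatter), read in this assay. On an aromatic carbon of the six-membered aromatic ring, ortho to a large group, the change from phenyl to 2-fluorophenyl thus leaves compound 2 and compound 3 within the usual scatter of each other, so this one position accepts fluoro with no readable shift in dose on the methyl-bearing core. Nothing measured here speaks to what lies behind this step.

On these data alone, whether a larger group at this same place, such as a methoxy, an amine or a trifluoromethyl on the core of compound 2, would also stay within the scatter remains open, as does whether fluoro on another carbon of the ring would read the same. Compound 1 does carry a trifluoromethyl, but its > 150 mg/kg is a limit and not a number, and it differs from compound 2 in more than one place, so it settles neither question.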